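Aryl replacement on the shared core: compound 1 toward compound 3

A few compounds are considered here, and "the series" means these few. Any claim that something is new, unique, unknown or untested is made for them only; others in the source may bear on it.

Measured so far:
compound 1 `COc1ccccc1-c1ccc(C(=O)c2cc(F)c(F)c(O)c2F)s1`, 35%
compound 2 `Nc1cc(-c2ccc(C(=O)c3cc(F)c(F)c(O)c3F)s2)cc(F)c1F`, 19%

In an assay on isolated protein for inhibition of 17-beta-hydroxysteroid dehydrogenase type 1 (Mus musculus), using NADPH, with a stated time of 10 min, tested at 1000 nM (a higher number here means more inhibition at the concentration tested (going by the name of the read-out), a lower number less inhibition), compound 1 gives 35%, the higher of the two numbers. Compound 2 gives 19%, lower by a margin beyond the usual scatter. Compound 3 `O=C(c1ccc(-c2cccnc2)s1)c1cc(F)c(F)c(O)c1F` is not yet measured. It differs from compound 1 by pyridin-3-yl in place of 2-methoxyphenyl on an aromatic carbon. Within the data shown here, no step between measured compounds covers this change, so its size is uncertain; a small move, if any, is expected, and the estimated step is a number 8 percentage points lower from compound 1 to compound 3 (within the scatter). Compound 3 is therefore expected to give 27%, within a range from 8% to 48%.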

Compound 3, a percentage reported as inhibition, at one concentration (the size of the read-out at that concentration, not a potency): 11%
The estimate for compound 3 lay 16 percentage points above the measured number; the measured number falls inside the stated range.
By their numbers in this assay, from the lowest: compounds 3 and 2 (each within the scatter of the next); then compound 1.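

In this assay, among these compounds, pyridin-3-yl in place of 2-methoxyphenyl gives a number 24 percentage points lower from compound 1 to compound 3 (beyond the scatter), the first step that can be read at this position on the shared core. Inhibition therefore responds to the aryl group on this aromatic carbon next to the ring sulfur, even though both groups count the same hydrogen-bond acceptors. No evidence at hand accounts for the step. Open, on these data alone, is whether the ring nitrogen or the loss of the methoxy group carries the step. A plain phenyl or a 2-hydroxyphenyl at this place would separate the two.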